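The source may report more compounds than this note shows. Statements on the series, on what has been measured and on what is new or still open speak of the compounds shown alone.

Compound 1 `C[C@H](Nc1nc(N)nc(N)c1C#N)c1cc2ccc(F)cn2c(=O)c1-c1ccccc1` gives 87% in an ADME assay on microsomes from liver (Homo sapiens), read by LC-MS, using NADPH, with a stated time of 30 min, tested at 1 uM; on this read-out higher numbers stand for a more stable compound and lower numbers for a less stable compound. Compound 2 `C[C@H](Nc1nc(N)ncc1C#N)c1cc2ccc(F)cn2c(=O)c1-c1ccccc1` gives 90% in this assay. Among these two numbers, compound 1 and compound 2 lie within the scatter of each other, as the step of a number 3 percentage points higher from compound 1 to compound 2 (within the scatter) shows. Compound 3 `COc1ccc(-c2c([C@H](C)Nc3nc(N)nc(N)c3C#N)c(-c3ccccc3)c(=O)n3cc(F)ccc23)cc1` has not yet been measured; it differs from compound 1 by 4-methoxyphenyl in place of hydrogen on an aromatic carbon. For the measured compounds named here, the one measured step exchanges amino for hydrogen, a change of another kind, so no measured step bears directly on this one. The step from compound 1 to compound 3 is expected to be a number 17 percentage points lower from compound 1 to compound 3 (beyond the scatter), a drop. Compound 3 is estimated at 70%, with a range from 40% to 95%.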

Compound 3, percent of the compound remaining: 89%
Compound 3: the middle estimate sits 19 percentage points below what was measured; the range from low to high includes it.
By their numbers in this assay, from the lowest: compounds 1, 3 and 2 (each within the scatter of the next).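

In this assay, the step from hydrogen to 4-methoxyphenyl on this aromatic carbon is a number 2 percentage points higher from compound 1 to compound 3 (within the scatter). A single hydrogen can therefore give way to a group of 8 heavy atoms, including a whole aromatic ring, at this position without a difference that can be told from scatter. Nothing shown accounts for this result.

Going by these compounds, whether a simple methyl, an amine or a carboxylic acid on the same carbon would read alike remains open. So does whether 4-methoxyphenyl would behave the same way on the core of compound 2.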